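Replacing iodo with methyl in compound 1

This account rests on a few compounds, and the source may have more. Where it says the series, first, only, none or still open, it means among the compounds named here.

Of the compounds shown here, two have numbers so far. In a functional assay on HUVEC cells (Homo sapiens), read by BrdU incorporation, with a stated time of 72 h (on this read-out higher numbers stand for weaker inhibition and lower numbers for stronger inhibition), compound 1 (`Cc1cccc2cc(/C=C/C(=O)c3ccc(I)s3)c(Cl)nc12`) gives 284 nM and stands highest of the two, so it is the weaker inhibitor here. Compound 2 (`Cc1ccc2cc(/C=C/C(=O)c3ccc(I)s3)c(Cl)nc2c1`) gives 135 nM as the lower number, and the gap between the two lies beyond the usual scatter.

The next compound to read is compound 3 (`Cc1ccc(C(=O)/C=C/c2cc3cccc(C)c3nc2Cl)s1`), which carries methyl in place of iodo on an aromatic carbon next to the ring sulfur. The same change reads 5-iodothiophen-2-yl to 5-methylthiophen-2-yl.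

Within the data shown here, no measured pair isolates this change, and the data hold no other group at this place, so its size cannot be read directly and the range is kept wide. A modest step toward weaker inhibition is expected, and a result within the scatter of compound 1 would also fit. The expected change is a 1.4-fold higher number from compound 1 to compound 3 (0.15 log units; within the scatter) on the higher side in this assay as a working figure. For compound 3 the estimate is 400 nM with an expected range from 130 nM to 1300 nM in this read-out.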

Compound 3, half-maximal inhibitory concentration: 145 nM
For compound 3 the middle estimate is 2.8-fold (0.44 log units) above the measured one; the range from low to high includes it.
By their numbers in this assay, from the lowest: compounds 2, 3 and 1 (each within the scatter of the next, the first and the last beyond it).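

In this assay, placing methyl instead of iodo on the aromatic carbon next to the ring sulfur gives a 2.0-fold lower number from compound 1 to compound 3 (0.29 log units; within the scatter) in this first direct reading of the change. The iodo group is therefore not required for a number of this size on the core of compound 1, and a single carbon in its place is enough to keep the read-out within the scatter of the parent compound. This is one pair on one core, so it shows that the two groups cannot be separated at this position in this assay, not that the position is indifferent to what it carries, and no available measurement offers an explanation for this result.

Among these compounds, still open is how this position responds to groups of a different kind, such as an amine, a carboxylic acid or a longer chain such as propyl, since iodo and methyl are the only two groups seen here. Also open, as far as these compounds go, is whether the change from 5-iodothiophen-2-yl to 5-methylthiophen-2-yl reads the same on the core of compound 2, where the methyl on the shared core sits elsewhere.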